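The source may report more compounds than this note shows. Statements on the series, on what has been measured and on what is new or still open speak of the compounds shown alone.

In a functional assay on the whole organism (strain Sprague-Dawley) for inhibition, with Rattus norvegicus as the target, with a stated time of 10 min (on this read-out higher numbers stand for an effect only at larger amounts of compound and lower numbers for an effect already at smaller amounts), the series starts from compound 1, `O=C(O)c1cnc(-c2ccccc2)[nH]c1=O`, which gives 50 mg/kg. Compound 2, `O=C(O)c1cnc(-c2ccccc2[N+](=O)[O-])[nH]c1=O`, differs from it by nitro in place of hydrogen on an aromatic carbon. In this assay compound 2 reaches only the limit of > 50 mg/kg, which is a limit of the assay and not a number. The step of a number no lower from compound 1 to compound 2 (the limit leaves the size open) therefore cannot be read beyond its direction, as recorded in the limit of > 50 mg/kg in this assay, at which 1 of the 3 values shown sits.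

Compound 3, `CCOC(=O)c1cnc(-c2cc([N+](=O)[O-])ccc2OCC)[nH]c1=O`, gives 5 mg/kg in this assay, the lowest of the two numbers shown; the difference between its core and that of compound 1 is not broken down here.

Compound 4, `CCOC(=O)c1cnc(-c2cc([N+](=O)[O-])cc([N+](=O)[O-])c2OCC)[nH]c1=O`, has not been measured. It differs from compound 3 by nitro in place of hydrogen on an aromatic carbon. For the measured compounds named here, this is the same kind of change as the one from compound 1 to compound 2, but the surroundings of the place differ: in compound 2 the new group sits ortho to a large group, whereas in compound 4 it sits ortho to an ethoxy group, meta to a large group and meta to a nitro group.

For compound 4 a step of a 2.4-fold higher number from compound 3 to compound 4 (0.38 log units; beyond the scatter) is expected, set beside the earlier a number no lower from compound 1 to compound 2 (the limit leaves the size open), which rests on the observation that adding a nitro group did not lower the number from compound 1 to compound 2. Compound 4 is accordingly estimated at 12 mg/kg in this assay, with a likely range from 4 mg/kg to 50 mg/kg.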

Compound 4, dose for 50% inhibition: > 50 mg/kg
Compound 4: no number, only a limit; the forecaster's own chance of this, stated with the estimate: 25%; at least 4.1-fold (0.61 log units) between middle value and limit.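

In this assay, compound 4 reaches only > 50 mg/kg, which is a limit of the assay and not a number. Nitro in place of hydrogen on an aromatic carbon here gives an at least 10-fold higher number from compound 3 to compound 4 (1.00 log units; beyond the scatter), so on both cores the change goes with no lowering of the number, and the direction carries from one core to the other in these two cases: the same change on two cores in this assay, a number no lower (the limit leaves the size open) from compound 1 to compound 2 and an at least 10-fold higher number (1.00 log units; beyond the scatter) from compound 3 to compound 4; the limit leaves it open whether they differ. What this does not show is whether the size of the step carries over as well, since the step on the core of compound 1 cannot be read in size and the values of compound 2 and compound 4 end at the same limit: the limit of > 50 mg/kg in this assay, at which 2 of the 4 values shown sit.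

The compounds shown leave open how the carboxylic acid and the ethyl ester compare on an otherwise identical core, and what the ethoxy group does on its own, as compound 1 and compound 3 differ in more than one place. They also leave open whether an amine or a chlorine atom at the place taken by the added nitro group in compound 4 would keep the number near that of compound 3, or whether a longer chain in place of the ethoxy group would shift it.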